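Swapping Cyano for Carbamoyl at a Tolerant Position

The source may report more compounds than this note shows. Statements on the series, on what has been measured and on what is new or still open speak of the compounds shown alone.

Measured so far, in an assay on isolated protein for inhibition of 2-Hydroxyacid oxidase 2 (Rattus norvegicus); on this read-out higher numbers stand for weaker inhibition and lower numbers for stronger inhibition:
Compound 1 `Cc1n[nH]c(C(=O)O)c1Cc1cccc(C(F)(F)F)c1` gives 300 nM.
Compound 2 `Cc1n[nH]c(C(=O)O)c1Cc1cccc(-c2ccccc2F)c1` gives 900 nM.
Compound 3 `Cc1n[nH]c(C(=O)O)c1Cc1cccc(C#N)c1` gives 500 nM.

Compound 3 stands second highest of these three numbers. Its nearest neighbour is compound 1, with a 1.7-fold higher number from compound 1 to compound 3 (0.22 log units; within the scatter), and its furthest is compound 2, with a 1.8-fold lower number from compound 2 to compound 3 (0.26 log units; within the scatter), so all three sit close together. Compound 4 `Cc1n[nH]c(C(=O)O)c1Cc1cccc(C(N)=O)c1` changes the same position once more: carbamoyl in place of cyano on an aromatic carbon. For the measured compounds named here, the steps that bear on this are those at that position; only a 3.0-fold higher number from compound 1 to compound 2 (0.48 log units; beyond the scatter) moved beyond the scatter, and none involves carbamoyl itself. The step of a 1.4-fold higher number from compound 3 to compound 4 (0.15 log units; within the scatter) is therefore expected to be small, likely within the scatter. For compound 4 the estimate is 700 nM, with a range from 250 nM to 2000 nM.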

Compound 4, half-maximal inhibitory concentration: 900 nM
Compound 4: the middle estimate sits 1.3-fold (0.11 log units) below what was measured; the measured number falls inside the stated range.
By their numbers in this assay, from the lowest: compounds 1, 3, 2 and 4 (each within the scatter of the next, the first and the last beyond it).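

In this assay, carbamoyl, which carries a hydrogen-bond donor where cyano has none, stays within the scatter of cyano (a 1.8-fold higher number from compound 3 to compound 4 (0.26 log units; within the scatter)) and of 2-fluorophenyl (no change at the digits printed from compound 2 to compound 4 (within the scatter)). Only trifluoromethyl separates from it (a 3.0-fold higher number from compound 1 to compound 4 (0.48 log units; beyond the scatter)), so compound 1 is now beyond the scatter of two of the other groups at this position. No measurement shown here offers an explanation for these steps. Still open, as far as these compounds go, is whether an amine or a carboxylic acid at this position would stay in the same range. Also open, from the compounds shown here alone, is whether adding a methyl group to the carbamoyl nitrogen would shift the number.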